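From a pentyloxy chain to fluoro on a shared core

The source may report more compounds than this note shows. Statements on the series, on what has been measured and on what is new or still open speak of the compounds shown alone.

Compound 1 `CCCCCOc1ccc2oc(/C=C/[S+](C)[O-])cc(=O)c2c1` gives 1600 nM
Compound 2 `COc1ccc2c(=O)cc(/C=C/[S+](C)[O-])oc2c1` gives 2200 nM

Among the measured compounds shown here, in a functional assay on A549 cells (Homo sapiens) for cytotoxicity, with a stated time of 48 h (a lower number here means a stronger inhibitor, a higher number a weaker inhibitor), compound 1 gives 1600 nM as one of just two numbers so far. Compound 2 gives 2200 nM in the same test, and the two lie within the usual scatter of each other, so neither can be ranked over the other.

Compound 3 `C[S+]([O-])/C=C/c1cc(=O)c2cc(F)ccc2o1` has not been measured yet. It keeps the core of compound 1 but carries fluoro in place of pentyloxy on an aromatic carbon and so loses the whole chain. For the measured compounds named here, no measured pair shows what this exchange does, which leaves any forecast uncertain. Going by the values given here, the only guide is compound 2, whose 2200 nM stays within the scatter of compound 1, so a moderate step is expected rather than a very large one. The expected step of a 1.9-fold higher number from compound 1 to compound 3 (0.27 log units; within the scatter) points toward a higher number in this assay, meaning a weaker inhibitor, though a result within the scatter would be no surprise. For compound 3 the estimated value is 3000 nM, with an expected range from 900 nM to 9000 nM in this test.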

Compound 3, half-maximal inhibitory concentration: 2100 nM
Compound 3: middle estimate off by 1.4-fold (0.15 log units), on the high side; the measured number falls inside the stated range.
By their numbers in this assay, from the lowest: compounds 1, 3 and 2 (each within the scatter of the next).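

Exchanging pentyloxy for fluoro on this aromatic carbon gives a 1.3-fold higher number from compound 1 to compound 3 (0.12 log units; within the scatter) in this assay, so compound 1 and compound 3 cannot be ranked against each other. Among the compounds shown here, this is the first direct comparison at this position, and it shows that removing the whole pentyloxy chain and leaving only a single fluorine atom produces no difference that can be read beyond normal measurement variation; on this core, the full chain is therefore not needed to reach a value of this size. No supporting data accompany this result to explain why the exchange makes so little difference.

On these data alone, a single pair cannot show whether this position is insensitive to other changes, so it remains open whether an amine, a carboxylic acid or a chain longer than pentyloxy here would give a step beyond the scatter. As far as these compounds go, it is also open what a plain hydrogen on this carbon would give, and that comparison would show whether either fluoro or pentyloxy contributes anything to the value at all.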